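Methylsulfanyl for methyl on the fused core: expected effect

This account rests on a few compounds, and the source may have more. Where it says the series, first, only, none or still open, it means among the compounds named here.

Measured so far:
compound 1, `COc1cc(C)nc2n/c(=N/C(=O)c3c(-c4ccc(Cl)cc4Cl)noc3C)sn12` — 80.5%
compound 2, `CSc1cc(C)nc2n/c(=N/C(=O)c3c(-c4ccc(Cl)cc4Cl)noc3C)sn12` — 75.4%

Both numbers come from a functional assay on the whole organism (strain L.) for inhibition, with Echinochloa crus-galli as the target, with a stated time of 72 h, tested at 100 mg/L; on this read-out higher numbers stand for more inhibition of growth at the one concentration tested and lower numbers for less inhibition of growth. Compound 1 and compound 2 lie within the scatter of each other; the step of a number 5.1 percentage points lower from compound 1 to compound 2 (within the scatter) is too small to count as a change, so neither number stands apart.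

Compound 3, `COc1cc(SC)nc2n/c(=N/C(=O)c3c(-c4ccc(Cl)cc4Cl)noc3C)sn12`, differs from compound 1 in one place: methylsulfanyl in place of methyl on an aromatic carbon. Within the data shown here, no measured pair shows this exact exchange. Among the measured compounds shown here, the only step available, a number 5.1 percentage points lower from compound 1 to compound 2 (within the scatter), concerns the neighboring methoxy group and shows that trading an oxygen-linked methyl for a sulfur-linked methyl on the same ring left the read-out within the scatter. By that single precedent, no step beyond the scatter is expected for compound 3 either, in either direction.

Compound 3 is therefore expected to give 76%, with a range from 60% to 90%. The expected step is a number 4.5 percentage points lower from compound 1 to compound 3 (within the scatter).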

Compound 3, percent growth inhibition at one concentration: 55.6%
Estimate against measurement, compound 3: 20.4 percentage points above, and the stated range ends above it.
By their numbers in this assay, from the lowest: compound 3; then compounds 2 and 1 (each within the scatter of the next).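

In this assay, among these compounds, the step of a number 24.9 percentage points lower from compound 1 to compound 3 (beyond the scatter) is the first change beyond the scatter, so the carbon opposite the ring nitrogen is not indifferent to what it carries. At this position, methylsulfanyl in place of methyl costs growth inhibition, whereas the exchange at the methoxy group, a number 5.1 percentage points lower from compound 1 to compound 2 (within the scatter), stayed within the scatter, so a tolerated methylsulfanyl at one place does not carry over to the other. Nothing available accounts for the loss at this position.

On these data alone, whether the loss follows the sulfur link or the greater length of the group stays open, and a methoxy group, an amine or an ethyl chain at this carbon would separate those readings. As far as these compounds go, whether any other group here exceeds methyl also remains open.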